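Swapping the para substituent on the sulfonamide aryl ring

The source may report more compounds than this note shows. Statements on the series, on what has been measured and on what is new or still open speak of the compounds shown alone.

Compound 1, `Cc1ccccc1S(=O)(=O)NC(C1=CC(=O)c2c(O)ccc(O)c2C1=O)C(C)C`: 790 nM
Compound 2, `CC(C)C(NS(=O)(=O)c1ccc(F)cc1)C1=CC(=O)c2c(O)ccc(O)c2C1=O`: 6650 nM
Compound 3, `CC(C)C(NS(=O)(=O)c1ccc(Br)cc1)C1=CC(=O)c2c(O)ccc(O)c2C1=O`: 7650 nM

Of the compounds shown here, three sharing one core have been tested in a functional assay on HeLa cells (Homo sapiens) for cytotoxicity, read by sulforhodamine B assay; on this read-out lower numbers stand for stronger inhibition and higher numbers for weaker inhibition. Compound 1 gives the lowest number of the three. Compound 3 stands at the highest number; its nearest neighbour is compound 2, and the two sit within the scatter of each other, while the gap to compound 1 is beyond the scatter, as a 9.7-fold higher number from compound 1 to compound 3 (0.99 log units; beyond the scatter) shows.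

Compound 4, `CC(=O)c1ccc(S(=O)(=O)NC(C2=CC(=O)c3c(O)ccc(O)c3C2=O)C(C)C)cc1`, has not yet been measured. It differs from compound 3 in one place: acetyl in place of bromo on an aromatic carbon.

The step that bears most directly on this is a 1.2-fold higher number from compound 2 to compound 3 (0.06 log units; within the scatter), in which one group on the same aromatic carbon was exchanged for another without a change beyond the scatter. The larger steps, an 8.4-fold higher number from compound 1 to compound 2 (0.93 log units; beyond the scatter) and a 9.7-fold higher number from compound 1 to compound 3 (0.99 log units; beyond the scatter), involve a different position and do not speak to an exchange at this carbon. On that basis compound 4 is expected to show a step of a 1.1-fold lower number from compound 3 to compound 4 (0.04 log units; within the scatter) in this assay, that is, none beyond the scatter. The estimate for compound 4 is therefore 7000 nM, with a range from 2500 nM to 20000 nM.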

Compound 4, half-maximal inhibitory concentration: 3820 nM
The estimate for compound 4 lay 1.8-fold (0.26 log units) above the measured number; the range from low to high includes it.
By their numbers in this assay, from the lowest: compound 1; then compounds 4, 2 and 3 (each within the scatter of the next).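

In this assay, acetyl brings three heavy atoms and a hydrogen-bond acceptor to this aromatic carbon where bromo had one heavy atom and no acceptor, yet the result remains within the scatter, with a 2.0-fold lower number from compound 3 to compound 4 (0.30 log units; within the scatter) and a 1.7-fold lower number from compound 2 to compound 4 (0.24 log units; within the scatter). Fluoro, bromo and acetyl at this carbon therefore cannot be told apart in this assay, while the exchange for 2-methylphenyl still matters, as a 4.8-fold higher number from compound 1 to compound 4 (0.68 log units; beyond the scatter) shows. No measurement bears on why these groups behave alike here.

The compounds shown leave open whether an amine or a carboxylic acid on this aromatic carbon would also stay within the scatter of these three. Going by these compounds, it is also open whether a 4-methylphenyl group would give a number nearer compound 1 or compound 3.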